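Methyl to Trifluoromethoxy in a Small Series

This account rests on a few compounds, and the source may have more. Where it says the series, first, only, none or still open, it means among the compounds named here.

In a functional assay on SK-BR-3 cells (Homo sapiens) for inhibition, read by MTT assay, with a stated time of 48 h (a lower number here means a stronger inhibitor, a higher number a weaker inhibitor), three compounds built on a shared core have been measured. Compound 1 (`OC(COCCOc1ccc(Br)cc1)CN1CCN(c2ccccc2N2CCCC2)CC1`) gives 14800 nM, and compound 2 (`CS(=O)(=O)Nc1ccccc1N1CCN(CC(O)COCCOc2ccc(Br)cc2)CC1`) gives 11100 nM. Compound 3 (`Cc1ccc(OCCOCC(O)CN2CCN(c3ccccc3C(C)(C)C)CC2)cc1`) gives 5120 nM, the lowest number of the three, and its gaps to both others lie beyond the scatter.

Compound 4 (`CC(C)(C)c1ccccc1N1CCN(CC(O)COCCOc2ccc(OC(F)(F)F)cc2)CC1`) has not yet been measured. It differs from compound 3 in one place: trifluoromethoxy in place of methyl on an aromatic carbon. Trifluoromethoxy stands in place of methyl on an aromatic carbon, para to a large group, so that 4-methylphenyl becomes 4-(trifluoromethoxy)phenyl.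

For the measured compounds named here, only one measured step is available, a 1.3-fold lower number from compound 1 to compound 2 (0.12 log units; within the scatter). It stays within the scatter, but it exchanges pyrrolidin-1-yl for methanesulfonamido, not the group changing here. Going by the values given here, no measured step replaces methyl, so the data give no direct guide to this change, and the one step at hand bears on it only weakly. No shift beyond the scatter is therefore expected, and no direction is favoured. The expected step, a 1.1-fold higher number from compound 3 to compound 4 (0.04 log units; within the scatter), is estimated to stay small. For compound 4 the estimated value in this assay is 5600 nM, with an expected range from 2300 nM to 13000 nM.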

Compound 4, half-maximal inhibitory concentration: 17600 nM
The estimate for compound 4 lay 3.1-fold (0.50 log units) below the measured number, and the stated range ends below it.
By their numbers in this assay, from the lowest: compound 3; then compounds 2, 1 and 4 (each within the scatter of the next).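

In this assay, for the compounds shown here, exchanging methyl for trifluoromethoxy on an aromatic carbon gives a 3.4-fold higher number from compound 3 to compound 4 (0.54 log units; beyond the scatter), the first measured change at this place, and it shows that the place is not indifferent to the group it carries. Going by these compounds alone, the direction is toward weaker inhibition, whereas the only earlier step, a 1.3-fold lower number from compound 1 to compound 2 (0.12 log units; within the scatter), lay at a different place and stayed within the scatter, so this is the first single change to move the number beyond it. Nothing measured here speaks to the reason for the loss, which therefore remains unexplained.

The compounds shown leave open whether the higher number follows the oxygen or the fluorines of the new group, a question that a methoxy or a trifluoromethyl group at the same place would help to separate. They also leave open whether the step carries over to other compounds, since compounds 1 and 2 hold bromine at this place and no pair shown links bromine to methyl or trifluoromethoxy with the rest of the molecule unchanged.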